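The source may report more compounds than this note shows. Statements on the series, on what has been measured and on what is new or still open speak of the compounds shown alone.

Measured in a functional assay on BXPC-3 cells (Homo sapiens) for antiproliferative activity, read by MTT assay, with a stated time of 24 h; a lower number here means a stronger inhibitor, a higher number a weaker inhibitor:
compound 1 `CCn1c(C(=O)NCCCO)ccc1C(CC)(CC)c1ccc(OCS(=O)(=O)c2ccccc2)c(C)c1`: 26600 nM
compound 2 `CCn1c(C(=O)N[C@H](CO)CCO)ccc1C(CC)(CC)c1ccc(OCS(=O)(=O)c2ccccc2)c(C)c1`: 15900 nM
compound 3 `CCn1c(C(=O)N[C@H](CO)CCCO)ccc1C(CC)(CC)c1ccc(OCS(=O)(=O)c2ccccc2)c(C)c1`: > 50000 nM, a limit and not a number

Compound 3 stands only at the limit of > 50000 nM in this assay, at which 1 of the 3 values shown sits. Compound 4 `CCn1c(C(=O)N[C@H](C)C(=O)O)ccc1C(CC)(CC)c1ccc(OCS(=O)(=O)c2ccccc2)c(C)c1` differs by a group of 5 heavy atoms (3 carbon, 2 oxygen; no ring) in place of a group of 7 heavy atoms (5 carbon, 2 oxygen; no ring), on an amide-type nitrogen. All three measured steps change the group on that amide-type nitrogen: a 1.7-fold lower number from compound 1 to compound 2 (0.22 log units; within the scatter), an at least 1.8-fold higher number from compound 1 to compound 3 (0.27 log units; that floor lies within the scatter) and an at least 3.1-fold higher number from compound 2 to compound 3 (0.49 log units; beyond the scatter). Only the last lies beyond the scatter. Among the measured compounds shown here, none of the measured compounds carries 1-carboxyethyl, so these steps are a rough guide. With a smaller group than in compound 3, the expectation leans on compound 1 at 26600 nM. The expected step is an at least 1.7-fold lower number from compound 3 to compound 4 (0.25 log units; that floor lies within the scatter), modest and towards a lower number in this assay, though another limit remains possible. Compound 4 is estimated at 28000 nM, with an expected range of 10000 nM to 50000 nM.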

Compound 4, half-maximal inhibitory concentration: 20100 nM
For compound 4 the middle estimate is 1.4-fold (0.14 log units) above the measured one, within the range that was stated.
By their numbers in this assay, from the lowest: compounds 2, 4 and 1 (each within the scatter of the next). At a limit, above all of these: compound 3.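

In this assay, 1-carboxyethyl on the amide-type nitrogen gives an at least 2.4-fold lower number from compound 3 to compound 4 (0.39 log units; beyond the scatter). Compound 3 is a limit and not a number, so that step is only a floor: the limit of > 50000 nM in this assay, at which 1 of the 4 values shown sits. Set against the two hydroxylated groups, 1-carboxyethyl shows a 1.3-fold higher number from compound 2 to compound 4 (0.10 log units; within the scatter) and a 1.3-fold lower number from compound 1 to compound 4 (0.12 log units; within the scatter), so in this assay this position accepts a carboxylic acid group without a readable change from compound 1 or compound 2.

Open, from the compounds shown here alone, is whether an amine or a longer carboxylic acid chain on this nitrogen stays with compound 1, compound 2 and compound 4 or reaches a limit like compound 3. Going by these compounds, the opposite configuration of 1-carboxyethyl also remains open.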